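The source may hold more compounds than are shown below. What is called first, only, known or untested is meant among the compounds shown, and "the series" means these compounds.

Three compounds share one core and differ only in a single group on an aromatic carbon. Compound 1 `O=S(=O)(Oc1ccc(Br)cc1)C1CC2OC1C(c1ccc(/C=C/c3cc(O)cc(O)c3)cc1)=C2c1ccc(O)cc1` gives 16900 nM in a functional assay on MCF7 cells (Homo sapiens) for antiproliferative activity, read by MTT assay, with a stated time of 72 h; on this read-out higher numbers stand for weaker inhibition and lower numbers for stronger inhibition. Compound 2 `O=S(=O)(Oc1ccc(Cl)cc1)C1CC2OC1C(c1ccc(/C=C/c3cc(O)cc(O)c3)cc1)=C2c1ccc(O)cc1` gives 17900 nM in this assay, and compound 3 `O=S(=O)(Oc1ccc(O)cc1)C1CC2OC1C(c1ccc(/C=C/c3cc(O)cc(O)c3)cc1)=C2c1ccc(O)cc1` gives 14100 nM. The three numbers lie within the scatter of one another: the step of a 1.1-fold higher number from compound 1 to compound 2 (0.02 log units; within the scatter), the step of a 1.3-fold lower number from compound 2 to compound 3 (0.10 log units; within the scatter) and the step of a 1.2-fold lower number from compound 1 to compound 3 (0.08 log units; within the scatter) are each within the scatter, so compound 2 stands level with compounds 1 and 3 rather than apart from them.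

Compound 4 `Cc1ccc(OS(=O)(=O)C2CC3OC2C(c2ccc(/C=C/c4cc(O)cc(O)c4)cc2)=C3c2ccc(O)cc2)cc1` has not yet been measured in this assay. From compound 2 it differs by methyl in place of chloro on an aromatic carbon, so that (4-chlorophenoxy)sulfonyl becomes (4-methylphenoxy)sulfonyl. Among the compounds with values here, no measured step exchanges chloro for methyl; the steps that bear on it are the three above, in which bromo, chloro and hydroxy on the same aromatic carbon all gave numbers within the scatter. The step from compound 2 to compound 4 is therefore expected to be none beyond the scatter, a 1.1-fold lower number from compound 2 to compound 4 (0.02 log units; within the scatter). Compound 4 is accordingly expected to give 17000 nM in this assay, with a range from 9000 nM to 32000 nM.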

Compound 4, half-maximal inhibitory concentration: 9200 nM
Compound 4: middle estimate off by 1.8-fold (0.27 log units), on the high side; the range from low to high includes it.
By their numbers in this assay, from the lowest: compounds 4, 3, 1 and 2 (each within the scatter of the next).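

In this assay, a carbon group on this aromatic carbon behaves like the halogens and the hydroxy group, as methyl stays within the scatter of all three: (a 1.9-fold lower number from compound 2 to compound 4 (0.29 log units; within the scatter)), (a 1.5-fold lower number from compound 3 to compound 4 (0.19 log units; within the scatter)) and (a 1.8-fold lower number from compound 1 to compound 4 (0.26 log units; within the scatter)). Within the data shown here, the step from chloro is the largest so far, yet even this step does not separate two compounds, so bromo, chloro, hydroxy and methyl cannot be ranked at this place. Nothing shown explains why the four numbers stand level.

Open, on these data alone, is whether an amine, a carboxylic acid or a longer chain on this aromatic carbon would stay within the scatter. Also open, as far as these compounds go, is whether any group here can move the number beyond the scatter, since all four compounds stand level.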